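Extending the chain and swapping the thiourea for a urea

The source may hold more compounds than are shown below. What is called first, only, known or untested is meant among the compounds shown, and "the series" means these compounds.

Two compounds share a core and differ only in the group attached to one nitrogen. Compound 1 `CNC(=S)NCCC(O)c1cc(Cl)ccc1N` gives 22.1% in an assay for inhibition of Nitric oxide synthase, inducible (Homo sapiens), read by scintillation counting, with a stated time of 30 min, tested at 1 mM; on this read-out lower numbers stand for less inhibition and higher numbers for more inhibition at the one concentration tested (going by the name of the read-out). Among the compounds with values here, compound 2 `CCNC(=S)NCCC(O)c1cc(Cl)ccc1N` gives 60.4% in this assay and so stands at the higher of the two numbers, with compound 1 its only neighbour, a step of a number 38.3 percentage points higher from compound 1 to compound 2 (beyond the scatter).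

Compound 3 `CCCNC(=O)NCCC(O)c1cc(Cl)ccc1N` has not been measured. It differs from compound 2 by a group of 6 heavy atoms (4 carbon, 1 nitrogen, 1 oxygen; no ring) in place of a group of 5 heavy atoms (3 carbon, 1 nitrogen, 1 sulfur; no ring), on an amine nitrogen. Within the data shown here, the one measured step, from a hydrogen to a methyl on the chain carbon bound to the amide-type nitrogen, was large and upward, and the change to compound 3 again lengthens that chain by one carbon. Among the measured compounds shown here, it also replaces sulfur with oxygen in the thiocarbonyl, a change for which no measured step exists. The chain extension alone would suggest a further rise, but the unmeasured sulfur-to-oxygen exchange leaves the direction open.

Compound 3 is therefore expected to show a step of a number 10.4 percentage points lower from compound 2 to compound 3 (beyond the scatter) in this assay, which means an estimate of 50%, most likely between 15% and 80%.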

Compound 3, a percentage reported as inhibition, at one concentration (the size of the read-out at that concentration, not a potency): 19.6%
Beside the measured number, compound 3's estimate is 30.4 percentage points above it; low and high end bracket the measured number.
By their numbers in this assay, from the lowest: compounds 3 and 1 (each within the scatter of the next); then compound 2.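

In this assay, the gain seen with a number 38.3 percentage points higher from compound 1 to compound 2 (beyond the scatter) does not carry over to the propylcarbamoyl group, which brings a number 40.8 percentage points lower from compound 2 to compound 3 (beyond the scatter). The longer chain therefore offers no simple route to a higher number here, since a number 2.5 percentage points lower from compound 1 to compound 3 (within the scatter) places the propyl urea level with the methyl thiourea. This step changes the chain length and exchanges sulfur for oxygen at the same time, so these compounds cannot show how much each change contributes, and no supporting measurement is available to explain the drop.

From the compounds shown here alone, a propyl chain on the thiourea and an ethyl chain on the urea remain open, and these two compounds would separate the effect of chain length from that of the sulfur-to-oxygen exchange. Also open, going by these compounds, is how a butyl chain or a cyclopropyl group on this nitrogen would read out, in either the thiourea or the urea series.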